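Working notes: the step from compound 2 to compound 3

The source may report more compounds than this note shows. Statements on the series, on what has been measured and on what is new or still open speak of the compounds shown alone.

Of the compounds shown here, two have been measured in a physicochemical assay for lipophilicity; on this read-out lower numbers stand for lower lipophilicity and higher numbers for higher lipophilicity. Compound 1 `Cc1ccc(NC(=O)CCc2nnc(CCCC(C)C)n2C2CC2)c(C)c1` gives 3.9 in this assay, and compound 2 `Cc1ccc(NC(=O)C[C@H](CCC(=O)O)c2noc(-c3ncc(CC(C)C)o3)c2C2CC2)c(Cl)c1` gives 3.7 in this assay. These two numbers lie within the usual scatter of each other, so no ordering between them is read. Compound 3 `Cc1ccc(NC(=O)C[C@H](CCC(=O)O)c2noc(-c3cc(CC(C)(C)C)on3)c2C2CC2)c(Cl)c1` has not been measured. It differs from compound 2 in one place: 5-neopentyl-1,2-oxazol-3-yl in place of 5-isobutyl-1,3-oxazol-2-yl on an aromatic carbon. Within the data shown here, with no step between measured compounds to lean on, a modest upward step is expected, possibly just beyond the scatter: a number 0.40 log units higher from compound 2 to compound 3 (beyond the scatter). For compound 3 the estimate in this assay is 4.1, with a range from 3.6 to 4.6.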

Compound 3, distribution coefficient: 4.2
The estimate for compound 3 lay 0.10 log units below the measured number; low and high end bracket the measured number.
By their numbers in this assay, from the lowest: compounds 2, 1 and 3 (each within the scatter of the next, the first and the last beyond it).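

In this assay, among these compounds, at this position on an aromatic carbon next to the ring oxygen, 5-neopentyl-1,2-oxazol-3-yl in place of 5-isobutyl-1,3-oxazol-2-yl gives a number 0.50 log units higher from compound 2 to compound 3 (beyond the scatter) and so provides the first single-place step. The entering group differs in both its ring and its chain, with 10 heavy atoms against 9, so the step cannot be divided between the two. No supporting measurement bears on the origin of this step. Going by these compounds, whether the ring or the chain carries the step stays open. Also open, on these data alone, is what an amine or a longer chain at this position would give in this assay.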